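The compounds below may be only part of what the source reports. "The series", "measured", "known", "first", "only" and "open" are said of these compounds alone.

Working notes on the series. In a functional assay on HCT-116 cells (Homo sapiens) for antiproliferative activity, read by MTT assay, with a stated time of 48 h (on this read-out higher numbers stand for weaker inhibition and lower numbers for stronger inhibition), compound 1 `CCCCC(CCO)n1cnc2c(N)ncnc21` gives > 50000 nM. That value is a limit of the assay and not a number. Within the data shown here, compound 2 `CCCCCCCCCCCC(CCO)n1cnc2c(NC)ncnc21` gives 15400 nM in this assay, the only actual number available so far, so it has no measured neighbour to be ranked against.

Compound 3 `CCCCCCCCCCCC(CCO)n1cnc2c(N)ncnc21` is the next one to read. It has hydrogen in place of methyl on a nitrogen on an aromatic ring, with methylamino going to amino: hydrogen in place of methyl on a nitrogen on an aromatic ring. Among the measured compounds shown here, no measured step covers this change, so the expectation in this assay is cautious: no shift beyond the scatter in either direction. The estimated step is a 1.0-fold lower number from compound 2 to compound 3 (0.01 log units; within the scatter). For compound 3 the expected value is 15000 nM, with an estimated range of 6000 nM to 40000 nM.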

Compound 3, half-maximal inhibitory concentration: 13400 nM
The estimate for compound 3 lay 1.1-fold (0.05 log units) above the measured number, and the stated range covers the measured number.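

In this assay, hydrogen in place of methyl on a nitrogen on an aromatic ring gives a 1.1-fold lower number from compound 2 to compound 3 (0.06 log units; within the scatter) and so does not separate methylamino from amino on the long-chain compounds. Heptyl in place of hydrogen on a saturated chain carbon, five bonds along the chain from an aromatic nitrogen, gives an at least 3.7-fold lower number from compound 1 to compound 3 (0.57 log units; beyond the scatter) and is the only step in the series printed as beyond the scatter, placing the measurable activity with the longer chain. As far as these compounds go, the value for compound 1 is a limit of the assay and not a number, so the true size of that step stays open: the limit of > 50000 nM in this assay, at which 1 of the 3 values shown sits.

Open, from the compounds shown here alone, is whether a still longer chain or one of intermediate length moves the number further. Also open, going by these compounds, is how an ethylamino group on the same nitrogen, or a carboxylic acid in place of the hydroxyl, would read in this assay on this core.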